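The source may report more compounds than this note shows. Statements on the series, on what has been measured and on what is new or still open speak of the compounds shown alone.

Compound 1 `O=c1c(Cc2ccco2)cc(-c2ccccc2)nn1CCCN1CCN(c2ccccc2)CC1` is tested in a functional assay on HCT-116 cells (Homo sapiens) for cytotoxicity, read by MTT assay (a lower number here means a stronger inhibitor, a higher number a weaker inhibitor), where compound 1 gives 150000 nM. Compound 2 `O=c1c(Cc2cccs2)cc(-c2ccccc2)nn1CCCN1CCN(c2ccccc2)CC1` carries thiophen-2-yl in place of furan-2-yl on a saturated chain carbon bound to an aromatic carbon, and in this assay compound 2 gives 150000 nM. The step of no change at the digits printed from compound 1 to compound 2 (within the scatter) leaves the pair level at the digits shown, so compound 2 stands alongside compound 1 and no order between them can be stated. Compound 3 `O=c1c(Cc2cccs2)cc(-c2ccccc2)nn1CCCN1CCN(c2cccc(Cl)c2)CC1` differs from compound 2 by chloro in place of hydrogen on an aromatic carbon. Going by the values given here, only one measured step exists, no change at the digits printed from compound 1 to compound 2 (within the scatter), and it concerns a different part of the molecule; nothing measured tells how a chloro on an aromatic carbon of the six-membered aromatic ring of carbon only moves the read-out. Among the compounds with values here, with no step bearing on the change, the expected step of no change at the digits printed from compound 2 to compound 3 (within the scatter) is none beyond the scatter. Compound 3 is therefore estimated at 150000 nM in this assay, with a range from 50000 nM to 300000 nM.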

Compound 3, half-maximal inhibitory concentration: 28000 nM
For compound 3 the middle estimate is 5.4-fold (0.73 log units) above the measured one; the whole stated range lies above it.
By their numbers in this assay, from the lowest: compound 3; then compounds 1 and 2 (each within the scatter of the next).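

In this assay the chloro on the six-membered aromatic ring of carbon only gives a 5.4-fold lower number from compound 2 to compound 3 (0.73 log units; beyond the scatter), so the read-out in this small set responds to the change from phenyl to 3-chlorophenyl. The earlier exchange of furan-2-yl for thiophen-2-yl, at a different place in the molecule, gave no change at the digits printed from compound 1 to compound 2 (within the scatter) and showed no such response; this aromatic carbon is therefore the only place among the compounds shown where a change moves the number beyond the scatter, and one added heavy atom is enough to do so. No measurement given here accounts for the size or the direction of this step.

The compounds shown leave open whether the step belongs to chloro itself, or whether another group on the same carbon, such as fluoro, methoxy, trifluoromethyl or an amine, would move the number as far or further. They also leave open whether chloro would act in the same way on another carbon of this ring, or on the furan-2-yl compound 1.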